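A few compounds are considered here, and "the series" means these few. Any claim that something is new, unique, unknown or untested is made for them only; others in the source may bear on it.

Measured so far:
compound 1 `O=C(c1ccc(-c2ccc3ncc(-c4ccc5ncccc5c4)n3c2)cc1)N1CCC(N2CCCCC2)CC1` — 2.41%
compound 2 `O=C(c1ccc(-c2ccc3ncc(-c4ccc5ncccc5c4)n3c2)cc1)N1CCNCC1` — 49.9%

In an assay on Sf21 cells for inhibition of MAP kinase-interacting serine/threonine-protein kinase 2 (Homo sapiens), read by luminescence and ADP-Glo, with stated times of 10 min and 40 min, tested at 500 nM (a higher number here means more inhibition at the concentration tested (going by the name of the read-out), a lower number less inhibition), compound 1 gives 2.41%, the lowest of the two numbers recorded; its nearest neighbour is compound 2, which gives 49.9%. Among the compounds with values here, the only measured step, a number 47.5 percentage points higher from compound 1 to compound 2 (beyond the scatter), changes the amine on the carbonyl carbon and leaves the quinolinyl group untouched.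

Compound 3 `O=C(c1ccc(-c2ccc3ncc(-c4cnc5ccccc5c4)n3c2)cc1)N1CCC(N2CCCCC2)CC1` differs from compound 1 by quinolin-3-yl in place of quinolin-6-yl on an aromatic carbon. Within the data shown here, no measured step changes this part of the shared core, so the single step from compound 1 to compound 2 does not bear directly on it and the expectation rests on the low starting point alone. The step from compound 1 to compound 3 is estimated as a number 9.6 percentage points higher from compound 1 to compound 3 (within the scatter), with either direction possible within the scatter. Compound 3 is expected to give 12% in this assay, in the range -5% to 40%.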

Compound 3, a percentage reported as inhibition, at one concentration (the size of the read-out at that concentration, not a potency): 48.8%
Beside the measured number, compound 3's estimate is 36.8 percentage points below it, outside the stated range (above it).
By their numbers in this assay, from the lowest: compound 1; then compounds 3 and 2 (each within the scatter of the next).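

At this position, on an aromatic carbon of a five-membered aromatic ring with 2 nitrogen, the attachment point of the quinoline matters: in this assay there is a number 46.4 percentage points higher from compound 1 to compound 3 (beyond the scatter) even though the group leaving and the group entering have the same atoms and the same counts of donors and acceptors. Until now, the only large change shown was on the carbonyl carbon, with a number 47.5 percentage points higher from compound 1 to compound 2 (beyond the scatter) at an unchanged quinolin-6-yl, whereas compound 3 keeps the 4-(piperidin-1-yl)piperidin-1-yl amide, so that amide does not rule out substantial inhibition in this series. No evidence at hand accounts for the step.

Going by these compounds, what piperazin-1-yl on the carbonyl carbon and quinolin-3-yl on the aromatic carbon give together in one compound remains open. So does the effect of a quinolin-5-yl or an isoquinolin-3-yl group at this position.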